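Substituting the Free Amine of Compound 2

A few compounds are considered here, and "the series" means these few. Any claim that something is new, unique, unknown or untested is made for them only; others in the source may bear on it.

Of the compounds shown here, two built on one shared core have so far been tested in a functional assay on the whole organism (strain albino) for inhibition, with Rattus norvegicus as the target, read by paw edema, with a stated time of 1 h, at a dose of 20 mmol/kg by the intraperitoneal route; a lower number here means less inhibition, a higher number more inhibition at the dose given (going by the name of the read-out). Compound 1 `N#CC1=C(/N=C/c2ccccc2)N(c2ccccc2)C(=O)N2CCCCC(N3CCCC3)C12` carries a benzylidene group on its ring amine and gives 46.5%. Compound 2 `N#CC1=C(N)N(c2ccccc2)C(=O)N2CCCCC(N3CCCC3)C12` has that ring amine left free, and compound 2 gives 77.9%. Of the two numbers, compound 2 stands highest, and the step of a number 31.4 percentage points higher from compound 1 to compound 2 (beyond the scatter) lies well beyond the scatter.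

Compound 3 `N#CC1=C(NCC(=O)N2CCCCC2)N(c2ccccc2)C(=O)N2CCCCC(N3CCCC3)C12` has not yet been measured. It differs from compound 2 by ((piperidin-1-yl)carbonyl)methyl in place of hydrogen on an amine nitrogen. Going by the values given here, the only measured step that bears on this change is the one from compound 1 to compound 2, in which removing the group on the amine nitrogen and leaving it free raised inhibition by a large margin. Putting a new group back onto that nitrogen, even one unlike the benzylidene, is therefore expected to cost some inhibition rather than add to it. For compound 3 the expected step is a number 22.9 percentage points lower from compound 2 to compound 3 (beyond the scatter). Compound 3 is thus estimated at 55%, with a range from 35% to 75%.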

Compound 3, a percentage reported as inhibition, in the whole organism at one dose (the size of the read-out at that dose, not a potency): 38%
Beside the measured number, compound 3's estimate is 17 percentage points above it; the measured number falls inside the stated range.
By their numbers in this assay, from the lowest: compounds 3 and 1 (each within the scatter of the next); then compound 2.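

In this assay, the step of a number 39.9 percentage points lower from compound 2 to compound 3 (beyond the scatter) shows that the loss on substituting this amine nitrogen is not confined to the benzylidene group of compound 1, since a quite different group, ((piperidin-1-yl)carbonyl)methyl, also leaves the free amine of compound 2 well ahead. The two substituents differ in build, one holding an aromatic ring of carbon only and the other a non-aromatic ring with a hetero atom and a carbonyl, yet the comparison a number 8.5 percentage points lower from compound 1 to compound 3 (within the scatter) means that these two compounds cannot be told apart here. Across these three compounds, then, the free amine stands alone at the top, but nothing available explains why either substituent lowers the read-out.

What the compounds shown leave open is whether a group as small as methyl on this nitrogen would keep the level of compound 2, or whether any substituent at all brings a loss. Going by these compounds, it also remains open how a longer chain, or a chain ending in a carboxylic acid or an amine, would fare at this position.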